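Trimming an Ethyl to a Methyl on a Shared Core

This account rests on a few compounds, and the source may have more. Where it says the series, first, only, none or still open, it means among the compounds named here.

Three compounds share one core. Compound 1 `Cc1cnc(CN(C)C[C@H]2Cc3c(cccc3N3CCNCC3)CN2)c(C)c1` has "not determined" (no result reported) in an ADME assay on microsomes from liver (Homo sapiens) for metabolic stability, read by LC-MS, with a stated time of 10 min; on this read-out higher numbers stand for a more stable compound and lower numbers for a less stable compound. Compound 2 `CCN(C[C@H]1Cc2c(cccc2N2CCNCC2)CN1)[C@H]1CCCc2cccnc21` gives 79.1% in this assay. Compound 3 `CN1CCN(c2cccc3c2C[C@H](CN(C)[C@H]2CCCc4cccnc42)NC3)CC1` gives 75.8% in this assay, a number that lies within the usual scatter of compound 2, so the two cannot be told apart on these data. Compound 4 `CN(C[C@H]1Cc2c(cccc2N2CCNCC2)CN1)[C@H]1CCCc2cccnc21` has not yet been measured. It differs from compound 2 in one place: hydrogen in place of methyl on a saturated chain carbon bound to an amine nitrogen. Among the compounds with values here, no measured pair here shows the effect of such a change, so the expectation rests on the small size of the change and on the value of compound 2, 79.1%. The step from compound 2 to compound 4 is expected to be a number 2.1 percentage points lower from compound 2 to compound 4 (within the scatter), none beyond the scatter. Compound 4 is therefore estimated at 77%, somewhere between 62% and 90%.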

Compound 4, percent of the compound remaining: 99.7%
Compound 4: middle estimate off by 22.7 percentage points, on the low side; the whole stated range lies below it.
By their numbers in this assay, from the lowest: compounds 3 and 2 (each within the scatter of the next); then compound 4.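

In this assay, within the data shown here, the single carbon at this place matters: going from ethyl to methyl, hydrogen in place of methyl on a saturated chain carbon bound to an amine nitrogen, gives a number 20.6 percentage points higher from compound 2 to compound 4 (beyond the scatter), a step the earlier compounds could not show. Hydrogen in place of methyl on an amine nitrogen in a ring likewise gives a number 23.9 percentage points higher from compound 3 to compound 4 (beyond the scatter), so small trims at two separate places each go with a higher number. Nothing measured here gives a reason for either step. Open, going by these compounds, is how a longer chain such as propyl would read at the first place. Also open, on these data alone, is whether a hydrogen in place of the remaining methyl would keep the number this high.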